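The source may hold more compounds than are shown below. What is called first, only, known or untested is meant among the compounds shown, and "the series" means these compounds.

The series shares one core, seen in compound 1 `COc1cc(OC)c2c(=O)cc(-c3ccc(OCCBr)cc3)oc2c1` and compound 2 `COc1cc(OC)c2c(=O)cc(-c3ccc(OCCF)cc3)oc2c1`, which carry a 2-bromoethoxy and a 2-fluoroethoxy group. In a functional assay (Homo sapiens) for antiproliferative activity, read by resazurin assay, with a stated time of 48 h, tested at 5 uM (a lower number here means a weaker effect, a higher number a stronger effect of the compound at the concentration tested), compound 1 gives "not active" (no number reported) and compound 2 gives "not active" (no number reported). Compound 3 `COc1cc(OC)c2c(=O)cc(-c3ccc(OCC(O)CN(C)C)cc3)oc2c1` is the only member with a reported number: in this assay compound 3 gives 42%, so it stands alone at the top of what is shown. Compound 4 `COc1cc(OC)c2c(=O)cc(-c3ccc(-c4ccc(F)nc4)cc3)oc2c1` differs from it as follows: 6-fluoropyridin-3-yl in place of 3-(dimethylamino)-2-hydroxypropoxy on an aromatic carbon. Going by the values given here, no measured pair shows the effect of such a change, so the step is uncertain; a modest downward step a number 12 percentage points lower from compound 3 to compound 4 (beyond the scatter) is expected, given that compound 3 reaches 42% while its two relatives report no number. Compound 4 is therefore estimated at 30%, within 5% to 60%.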

Compound 4, a percentage reported as inhibition, at one concentration (the size of the read-out at that concentration, not a potency): "not active" (no number reported)
No number was reported for compound 4, and the estimate cannot be compared.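

No step can be read from compound 3 to compound 4. No evidence bears on this result. The compounds shown leave open how much 6-fluoropyridin-3-yl in place of 3-(dimethylamino)-2-hydroxypropoxy changes the read-out in this assay.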